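The source may hold more compounds than are shown below. What is called first, only, known or untested is meant among the compounds shown, and "the series" means these compounds.

Compound 2 `COc1cccc(S(=O)(=O)N2CCC(N3CCC(C)CC3)CC2)c1` stands at the weak end of everything measured in a functional assay on DLD-1 cells (Homo sapiens) for antiproliferative activity, read by CellTiter-Glo, with a stated time of 72 h; on this read-out higher numbers stand for weaker inhibition and lower numbers for stronger inhibition. In this assay compound 2 gives only the limit > 5000 nM, with no number beneath it. Its measured neighbour, compound 1 `COc1ccccc1-c1cccc(S(=O)(=O)N2CCC(N3CCC(C)CC3)CC2)c1`, gives 21 nM in this assay. Among the measured compounds shown here, the single measured step, an at least 230-fold higher number from compound 1 to compound 2 (2.37 log units; beyond the scatter), is the only guide here, and on it the limit of > 5000 nM in this assay, at which 1 of the 2 values shown sits, holds for compound 2. Compound 3 `COc1ccc(S(=O)(=O)N2CCC(N3CCC(C)CC3)CC2)cc1OC` differs from compound 2 by methoxy in place of hydrogen on an aromatic carbon. In an at least 230-fold higher number from compound 1 to compound 2 (2.37 log units; beyond the scatter) the large loss went with removing the 2-methoxyphenyl group, and a second methoxy group is a far smaller addition than what was lost there. Compound 3 is therefore expected to show a step that the limit leaves unreadable from compound 2 to compound 3 in this assay, that is no step beyond the scatter. The estimate for compound 3 is 8000 nM, within a range of 2000 nM to 30000 nM, and most likely it is again reported only as a limit.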

Compound 3, half-maximal inhibitory concentration: 138 nM
The estimate for compound 3 lay 58-fold (1.76 log units) above the measured number; the measured number lies below the stated range.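

Putting methoxy in place of hydrogen on the aromatic carbon ortho to a methoxy group and para to a large group gave an at least 36-fold lower number from compound 2 to compound 3 (1.55 log units; beyond the scatter) in this assay. The earlier pair showed a large change only with the 2-methoxyphenyl group, whereas this step shows that a group of just 2 heavy atoms at this place can also carry a large change, with no 2-methoxyphenyl group present. The true size of the step cannot be read, only its lower bound, since compound 2 is held by a limit and not by a number: the limit of > 5000 nM in this assay, at which 1 of the 3 values shown sits.

Going by these compounds, what a hydroxyl or an amine at this place would give remains open. Also open, on these data alone, is whether the gain would persist with the 2-methoxyphenyl group present as well.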